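Chalcone Against Synovial Sarcoma Cells: Dropping the Chloro

The compounds below may be only part of what the source reports. "The series", "measured", "known", "first", "only" and "open" are said of these compounds alone.

Of the compounds shown here, three have so far been tested in a functional assay on SW982 cells (Homo sapiens) for inhibition, read by MTT assay, with a stated time of 72 h; on this read-out higher numbers stand for weaker inhibition and lower numbers for stronger inhibition. Compound 1 `COc1cc(OC)c(-c2cc(=O)c3cc(O)ccc3o2)cc1OC` gives in this assay > 150000 nM, which is a limit of the assay rather than a number. Compound 3 `COc1cc(OC)c(-c2cc(=O)c3ccc(O)cc3o2)cc1OC` gives in this assay > 150000 nM, again a limit. Going by the values given here, compound 2 `COc1cc(OC)c(OC)cc1/C=C/C(=O)c1ccc(Cl)c([N+](=O)[O-])c1` is the only compound with an actual number in this assay, at 20600 nM. The two further values shown are limits (the limit of > 150000 nM in this assay, at which 2 of the 3 values shown sit). Among the compounds with values here, no pair of measured compounds differs in a single place, so no measured step sets a scale for the change now in hand.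

Compound 4 `COc1cc(OC)c(OC)cc1/C=C/C(=O)c1cccc([N+](=O)[O-])c1` has not yet been measured in this assay. It differs from compound 2 by hydrogen in place of chloro on an aromatic carbon. Within the data shown here, with no measured step to lean on, the expected step from compound 2 to compound 4 is a 1.5-fold higher number from compound 2 to compound 4 (0.16 log units; within the scatter), a modest shift toward weaker inhibition that may well not exceed the usual scatter. Compound 4 is accordingly estimated to give in this assay about 30000 nM, within a range from 10000 nM to 100000 nM.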

Compound 4, half-maximal inhibitory concentration: 101000 nM
Beside the measured number, compound 4's estimate is 3.4-fold (0.53 log units) below it; measured number outside the range, above it.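

In this assay, going by these compounds alone, the chloro on this aromatic carbon, ortho to a nitro group, is the first single place where a change can be read, and it counts: hydrogen in its place gives a 4.9-fold higher number from compound 2 to compound 4 (0.69 log units; beyond the scatter). The step is modest but lies beyond the usual scatter, so the number of compound 2 rests in measurable part on this one chlorine atom. Compound 4 also stands close to the top of the read-out: the limit of > 150000 nM in this assay, at which 2 of the 4 values shown sit.

From the compounds shown here alone, whether a fluoro, a bromo, a methyl or a methoxy on this carbon would hold the number of compound 2 or pass it stays open, as does what an amine in place of the nitro group would do. Going by these compounds, this is a single pair at a single position, so how the step behaves on a different core remains unknown.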